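Replacing a pyrrole with an amino group on a kinase-binding core

The compounds below may be only part of what the source reports. "The series", "measured", "known", "first", "only" and "open" are said of these compounds alone.

Measured so far:
compound 1 `Cn1c(-n2cccc2)c(C#N)c2c(N)ncnc21` — 239 nM
compound 2 `C[C@@H]1CCCN1c1c(C#N)c2c(N)nc(Nc3cn[nH]c3)nc2n1C` — 0.2 nM

In an assay on isolated protein for binding affinity to Leucine-rich repeat serine/threonine-protein kinase 2 (Homo sapiens), read by TR-FRET and LanthaScreen, with a stated time of 2 h (on this read-out higher numbers stand for weaker inhibition and lower numbers for stronger inhibition), compound 1 gives 239 nM, the highest of the two numbers, while compound 2 gives 0.2 nM, a far lower number that lies beyond the scatter. Compound 3 `Cn1c(N)c(C#N)c2c(N)ncnc21` is not yet measured; it differs from compound 1 in one place: amino in place of 1H-pyrrol-1-yl on an aromatic carbon. For the measured compounds named here, no measured pair shows this exact change, so its size is uncertain. A moderate rise in the number, that is weaker binding, is expected, a 3.3-fold higher number from compound 1 to compound 3 (0.52 log units; beyond the scatter). Compound 3 is therefore estimated at 800 nM, within 150 nM to 4000 nM.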

Compound 3, inhibition constant: 346 nM
Compound 3: the middle estimate sits 2.3-fold (0.36 log units) above what was measured; measured number inside the range.
By their numbers in this assay, from the lowest: compound 2; then compounds 1 and 3 (each within the scatter of the next).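

In this assay putting amino in place of 1H-pyrrol-1-yl on this aromatic carbon gives a 1.4-fold higher number from compound 1 to compound 3 (0.16 log units; within the scatter) and so leaves the two compounds indistinguishable. The change removes a five-membered aromatic ring and adds a hydrogen-bond donor, yet binding shows no clear shift. Nothing measured here explains this tolerance. From the compounds shown here alone, whether a larger amine such as morpholine or a longer chain at this position would shift the number remains open. Compound 2 differs from both in more than one place, so the source of its much lower number is also unresolved.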